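Carbamate series: ring fluoro substitution on the aryl group

The compounds below may be only part of what the source reports. "The series", "measured", "known", "first", "only" and "open" are said of these compounds alone.

Measured so far:
compound 1 `C=C1C(=O)OC[C@@H]1CCOC(=O)Nc1ccc(CCCC)cc1` — 1230 nM
compound 2 `C=C1C(=O)OC[C@@H]1CCOC(=O)Nc1ccccc1` — 780 nM

Going by the values given here, in a functional assay on RAW264.7 cells (Mus musculus) for inhibition, with a stated time of 30 min (a lower number here means a stronger inhibitor, a higher number a weaker inhibitor), compound 2 gives the lowest of the two numbers so far; its nearest neighbour is compound 1, and the step of a 1.6-fold lower number from compound 1 to compound 2 (0.20 log units; within the scatter) is within the scatter, so the two cannot be ordered.

Compound 3 `C=C1C(=O)OC[C@@H]1CCOC(=O)Nc1ccccc1F` differs from compound 2 by fluoro in place of hydrogen on an aromatic carbon. Among the compounds with values here, no measured step changes this position or introduces a halogen. Within the data shown here, the only step available, from butyl to hydrogen on an aromatic carbon, stays within the scatter, giving no indication that a single ring substituent moves this assay by a large amount. Accordingly a step within the scatter is expected for compound 3, with a 1.0-fold lower number from compound 2 to compound 3 (0.02 log units; within the scatter) as the estimated change. For compound 3 the expected value in this assay is 750 nM, in a range from 300 nM to 1900 nM.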

Compound 3, half-maximal inhibitory concentration: 690 nM
Compound 3: middle estimate off by 1.1-fold (0.04 log units), on the high side; the measured number falls inside the stated range.
By their numbers in this assay, from the lowest: compounds 3, 2 and 1 (each within the scatter of the next).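

In this assay, going by these compounds alone, fluoro in place of hydrogen on an aromatic carbon, ortho to a large group, gives a 1.1-fold lower number from compound 2 to compound 3 (0.05 log units; within the scatter); this position, which the earlier compounds did not vary, therefore takes a single fluorine without a readable shift. Ring substitution has now been read in two places, and neither step lies beyond the scatter, the other being a 1.6-fold lower number from compound 1 to compound 2 (0.20 log units; within the scatter). No measured evidence bears on why the fluoro step is so small.

From the compounds shown here alone, whether methoxy, trifluoromethyl or an amine at this same position would move the number beyond the scatter stays open. Also open, going by these compounds, is whether fluoro elsewhere on the ring, or a second fluoro, would behave the same way in this assay.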